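A few compounds are considered here, and "the series" means these few. Any claim that something is new, unique, unknown or untested is made for them only; others in the source may bear on it.

Compound 1 `O=C1C=CC2(C=C1)OCC(=O)N2S(=O)(=O)c1ccccc1`: > 10000 nM
Compound 2 `Cc1ccccc1S(=O)(=O)N1C(=O)COC12C=CC(=O)C=C2`: > 10000 nM
Compound 3 `O=C1C=CC2(C=C1)OCC(=O)N2S(=O)(=O)c1ccccc1OC(F)(F)F`: > 10000 nM

All three entries come from a functional assay on MDA-MB-231 cells (Homo sapiens) for inhibition, read by sulforhodamine B assay, with a stated time of 74 h (on this read-out lower numbers stand for stronger inhibition and higher numbers for weaker inhibition), and each is a limit of the assay, not a number. Compound 3 therefore has no exact place in the series. Its entry of > 10000 nM is a limit too.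

Compound 4 `O=C1C=CC2(C=C1)OCC(=O)N2S(=O)(=O)c1ccccc1C(F)(F)F` has trifluoromethyl in place of trifluoromethoxy on an aromatic carbon, ortho to a large group: trifluoromethyl in place of trifluoromethoxy on an aromatic carbon.

Among the measured compounds shown here, three measured steps bear on this change, all of them swaps at this same place on the ring: a step that the two limits leave unreadable from compound 1 to compound 2, a step that the two limits leave unreadable from compound 1 to compound 3 and a step that the two limits leave unreadable from compound 2 to compound 3. None of them has a size that can be read. For compounds 1, 2 and 3, the evidence is the limit of > 10000 nM in this assay, at which 3 of the 3 values shown sit. So no step beyond the usual scatter is expected in this assay, and no direction is expected either.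

The estimated outcome is a step that the limit leaves unreadable from compound 3 to compound 4.

For compound 4 the estimated value is 12000 nM, with an expected range from 5000 nM to 30000 nM.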

Compound 4, half-maximal inhibitory concentration: > 10000 nM
Compound 4 ended at the assay's limit; the forecaster's own chance of this, stated with the estimate: 85%; the middle value does not contradict the limit.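

Compound 4 also ends at a limit of the assay rather than a number, so none of its steps from compound 1, compound 2 or compound 3 can be read: the limit of > 10000 nM in this assay, at which 4 of the 4 values shown sit. On these data alone, how strongly these four compounds act in this assay, and whether the swapped groups make any difference, stays open.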